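Second Acetyl on the Amide Nitrogen: Cytotoxicity Outlook

The source may hold more compounds than are shown below. What is called first, only, known or untested is meant among the compounds shown, and "the series" means these compounds.

Measured so far:
Compound 1 `O=C(NCc1ccccc1C(=O)N[C@H](/C=C/S(=O)(=O)c1ccccc1)CCc1ccccc1)c1cccc(O)c1` gives 36000 nM in a toxicity assay on J774.1 cells (Mus musculus) for cytotoxicity, read by MTT assay, with a stated time of 48 h; a lower number here means that less compound is tolerated, a higher number that more compound is tolerated.
Compound 2 `CC(=O)NCc1ccccc1C(=O)N[C@H](/C=C/S(=O)(=O)c1ccccc1)CCc1ccccc1` gives 48000 nM in this assay.

Compound 2 and compound 1 lie within the scatter of each other, so neither stands apart. Compound 3 `CC(=O)N(Cc1ccccc1C(=O)N[C@H](/C=C/S(=O)(=O)c1ccccc1)CCc1ccccc1)C(C)=O` differs from compound 2 by acetyl in place of hydrogen on an amide-type nitrogen. Within the data shown here, no measured step touches this nitrogen; the single step known, a 1.3-fold higher number from compound 1 to compound 2 (0.12 log units; within the scatter), concerns the carbonyl carbon of the same acetamido group and stayed within the scatter. Compound 3 is expected to show a step of a 1.1-fold lower number from compound 2 to compound 3 (0.03 log units; within the scatter), no change beyond the scatter. The value of compound 3 is estimated at 45000 nM, between 20000 nM and 100000 nM.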

Compound 3, half-maximal cytotoxic concentration: 36000 nM
Compound 3: the middle estimate sits 1.3-fold (0.10 log units) above what was measured; the measured number falls inside the stated range.
By their numbers in this assay, from the lowest: compounds 1, 3 and 2 (each within the scatter of the next).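

In this assay the acetyl taking the place of the amide hydrogen gives a 1.3-fold lower number from compound 2 to compound 3 (0.12 log units; within the scatter) and so this nitrogen, now without its hydrogen, shows no shift beyond the scatter. Diacetylamino in place of ((3-hydroxyphenyl)carbonyl)amino gives no change at the digits printed from compound 1 to compound 3 (within the scatter) so that all three compounds stand within the scatter of one another. Nothing at hand explains these numbers.

From the compounds shown here alone, whether a methyl or a longer chain on this nitrogen, or an amine or a carboxylic acid on the saturated chain carbon, would move the number beyond the scatter stays open.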